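This account rests on a few compounds, and the source may have more. Where it says the series, first, only, none or still open, it means among the compounds named here.

Of the compounds shown here, three sharing one core have been measured in an assay (strain Wistar) for displacement of a labelled ligand from adenosine receptor A1 (Rattus norvegicus), read by scintillation counting; on this read-out lower numbers stand for stronger inhibition and higher numbers for weaker inhibition. Compound 1 `O=C(Nc1nc(-c2ccccc2)nc2c1nnn2Cc1ccccc1)c1ccoc1` gives 10 nM, compound 2 `O=C(Nc1nc(-c2ccccc2)nc2c1nnn2Cc1ccccc1)C1CC1` gives 7.5 nM, and compound 3 `O=C(Nc1nc(-c2ccccc2)nc2c1nnn2Cc1ccccc1)c1ccccc1C(F)(F)F` gives 550 nM. Compound 3 therefore stands highest of the three, and the steps leading to it, a 55-fold higher number from compound 1 to compound 3 (1.74 log units; beyond the scatter) and a 73-fold higher number from compound 2 to compound 3 (1.87 log units; beyond the scatter), both lie far beyond the scatter, whereas the step of a 1.3-fold lower number from compound 1 to compound 2 (0.12 log units; within the scatter) stays within it.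

Compound 4 `Nc1ccc(C(=O)Nc2nc(-c3ccccc3)nc3c2nnn3Cc2ccccc2)cc1` is the next compound, and it differs from compound 3 in one place: 4-aminophenyl in place of 2-(trifluoromethyl)phenyl on a carbonyl carbon. Within the data shown here, no measured step exchanges one phenyl group for another, so the bearing of the earlier steps is indirect. What they do show is that the 2-(trifluoromethyl)phenyl group of compound 3 goes with a much higher number than either the furan-3-yl of compound 1 or the cyclopropyl of compound 2. Removing that group is expected to bring the number back down by a large amount, and the expected step is a 22-fold lower number from compound 3 to compound 4 (1.34 log units; beyond the scatter). Compound 4 is therefore estimated at 25 nM, with a range from 5 nM to 150 nM, most likely close to where compound 1 and compound 2 sit.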

Compound 4, inhibition constant: 7.1 nM
Compound 4: the middle estimate sits 3.5-fold (0.55 log units) above what was measured; the range from low to high includes it.
By their numbers in this assay, from the lowest: compounds 4, 2 and 1 (each within the scatter of the next); then compound 3.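

In this assay, a six-membered aromatic carbon ring on the carbonyl carbon does not by itself go with a high number: with that ring kept, there is a 77-fold lower number from compound 3 to compound 4 (1.89 log units; beyond the scatter) when 4-aminophenyl replaces 2-(trifluoromethyl)phenyl. The 4-aminophenyl group also matches the smaller groups, with a 1.1-fold lower number from compound 2 to compound 4 (0.02 log units; within the scatter) and a 1.4-fold lower number from compound 1 to compound 4 (0.15 log units; within the scatter), so compounds 1, 2 and 4 cannot be told apart at this position and only compound 3 stands away from them. Nothing available here bears on why the two substituted phenyl groups give such different numbers.

The compounds shown leave open whether the high number of compound 3 goes with the trifluoromethyl group itself or with where it sits on the ring, a question that 4-(trifluoromethyl)phenyl and 2-aminophenyl groups on the same carbonyl carbon would help to separate. They also leave open whether the amine contributes anything to the number of compound 4, which could be tested by comparison with an unsubstituted phenyl group.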